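The source may report more compounds than this note shows. Statements on the series, on what has been measured and on what is new or still open speak of the compounds shown alone.

Measured so far:
compound 1 `Brc1ccc2[nH]c(-c3cncn3Cc3ccc(-c4ccccc4)cc3)cc2c1` — 34200 nM
compound 2 `Cc1ccc(Cn2cncc2-c2cc3cc(Br)ccc3[nH]2)cc1` — 21600 nM

In an assay on isolated protein for inhibition of Indoleamine 2,3-dioxygenase 1 (Homo sapiens), with a stated time of 1 h (on this read-out lower numbers stand for stronger inhibition and higher numbers for weaker inhibition), compound 2 and compound 1 lie within the scatter of each other, with a 1.6-fold lower number from compound 1 to compound 2 (0.20 log units; within the scatter). Compound 3 `FC(F)(F)c1ccc(Cn2cncc2-c2cc3cc(Br)ccc3[nH]2)cc1` carries trifluoromethyl in place of methyl on an aromatic carbon. Going by the values given here, the only step touching that position is the one from compound 1 to compound 2, which stayed within the scatter; no other measured step bears on this change. No shift beyond the scatter is therefore expected, and for compound 3 the estimate is 22000 nM in this assay, within 7000 nM to 65000 nM, meaning an expected step of a 1.0-fold higher number from compound 2 to compound 3 (0.01 log units; within the scatter).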

Compound 3, half-maximal inhibitory concentration: > 100000 nM
Compound 3 gave a limit, no number; the forecaster's own chance of this, stated with the estimate: 15%; middle value at least 4.5-fold (0.65 log units) away from the limit.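

In this assay compound 3 gives only a limit of the assay, not a number: the limit of > 100000 nM in this assay, at which 1 of the 3 values shown sits. Phenyl and methyl on this aromatic carbon, para to a large group, stayed within the scatter of each other, so the earlier compounds showed no response at this place. Trifluoromethyl is the first group here to move the read-out beyond the scatter, with an at least 4.6-fold higher number from compound 2 to compound 3 (0.66 log units; beyond the scatter) and with an at least 2.9-fold higher number from compound 1 to compound 3 (0.46 log units; beyond the scatter). As far as these compounds go, the full size of both steps stays open. Also open, from the compounds shown here alone, is how a methoxy group, an amine or a carboxylic acid on the same carbon would read.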